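This account rests on a few compounds, and the source may have more. Where it says the series, first, only, none or still open, it means among the compounds named here.

Compound 1 `CC(O)(COc1ccc(C#N)cc1)C(=O)Nc1ccc(S(F)(F)(F)(F)F)cc1` and compound 2 `CC(O)(COc1ccc(C#N)cc1C(F)(F)F)C(=O)Nc1ccc(S(F)(F)(F)(F)F)cc1` share one core, and compound 3 `CC(O)(COc1ccc(C#N)cc1)C(=O)Nc1cccc(S(F)(F)(F)(F)F)c1` and compound 4 `CC(O)(COc1ccc(C#N)cc1C(F)(F)F)C(=O)Nc1cccc(S(F)(F)(F)(F)F)c1` share another; the difference between the two cores is not broken down here. In a functional assay on CWR22R cells (Homo sapiens) for antiproliferative activity, read by propidium iodide staining, with a stated time of 96 h (on this read-out lower numbers stand for stronger inhibition and higher numbers for weaker inhibition), compound 1 gives 26100 nM, and in this assay compound 2 gives 13800 nM. The change from compound 1 to compound 2 is trifluoromethyl in place of hydrogen on an aromatic carbon, and it produced a 1.9-fold lower number from compound 1 to compound 2 (0.28 log units; within the scatter). In this assay compound 3 gives 32500 nM, which sits beside the value of compound 1 and is further from that of compound 2. Compound 4 has not yet been measured. Within the data shown here, it differs from compound 3 by trifluoromethyl in place of hydrogen on an aromatic carbon, the same kind of change as the one from compound 1 to compound 2. Among the measured compounds shown here, since only a single earlier example of this change is available, the expectation for compound 4 rests on that one step alone, because a 1.9-fold lower number from compound 1 to compound 2 (0.28 log units; within the scatter) is the only guide. On that basis compound 4 is expected to show a 1.9-fold lower number from compound 3 to compound 4 (0.28 log units; within the scatter) in this assay. The estimated value for compound 4 in this assay is 17000 nM, with a likely range from 8000 nM to 36000 nM.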

Compound 4, half-maximal inhibitory concentration: 18300 nM
Beside the measured number, compound 4's estimate is 1.1-fold (0.03 log units) below it, and the stated range covers the measured number.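

On the core of compound 3, trifluoromethyl in place of hydrogen on an aromatic carbon gave a 1.8-fold lower number from compound 3 to compound 4 (0.25 log units; within the scatter) in this assay. Set beside the earlier step, the change reads the same on both cores: the same change on two cores in this assay, a 1.9-fold lower number (0.28 log units; within the scatter) from compound 1 to compound 2 and a 1.8-fold lower number (0.25 log units; within the scatter) from compound 3 to compound 4, 1.1-fold (0.03 log units) apart, within the scatter of two such steps. This shows that, for these two pairs, the step carried from one core to the other without a visible difference in size, but each step lies within the scatter, so neither pair alone establishes a real gain in activity, and two cores give no general rule for the series.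

The compounds shown leave open whether a methyl group, a chlorine atom or an amine on that same aromatic carbon would give a step of similar size on both cores. They also leave open whether a carboxylic acid in place of the nitrile would alter how the trifluoromethyl step carries over.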